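The source may hold more compounds than are shown below. What is called first, only, known or untested is meant among the compounds shown, and "the series" means these compounds.

Compound 1 `COc1cc(CNC(=S)NC(CCc2ccc(C(C)(C)C)cc2)COC(=O)C(C)(C)C)ccc1O` gives 36.5 nM in an assay on CHO cells for displacement of a labelled ligand from transient receptor potential cation channel subfamily V member 1 (Rattus norvegicus); a lower number here means a stronger inhibitor, a higher number a weaker inhibitor.
Compound 2 `COc1cc(CNC(=S)NCC(COC(=O)C(C)(C)C)Cc2ccc(C(C)(C)C)cc2)cc(Cl)c1O` gives 21.3 nM in this assay.
Compound 3 `COc1cc(CNC(=S)NC(CCc2ccc(C(C)(C)C)cc2)COC(=O)C(C)(C)C)cc(Cl)c1O` gives 122 nM in this assay.

Among the three measured compounds, compound 3 stands at the highest number. Going by the values given here, its nearest neighbour is compound 1, and the only single-point step in the set runs between them: a 3.3-fold higher number from compound 1 to compound 3 (0.52 log units; beyond the scatter), a change from hydrogen to chloro on the ring carrying the hydroxy and methoxy groups. Compound 2 sits further away still, with a lower number than compound 3, but it differs in more than one place, so that gap is only a comparison of two values.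

Compound 4 `COc1cc(CNC(=S)NC(CCc2ccc(C(C)(C)C)cc2)COC(=O)C(C)(C)C)cc(Br)c1O` is the next compound. It differs from compound 3 as follows: bromo in place of chloro on an aromatic carbon. Among the compounds with values here, no measured pair swaps one halogen for another, so nothing in the data speaks directly to this change; the hydrogen-to-chloro step is the closest reference but is of a different kind. The expectation is therefore a step that stays within the scatter, a 1.0-fold lower number from compound 3 to compound 4 (0.01 log units; within the scatter). Compound 4 is estimated at 120 nM in this assay, with a range from 50 nM to 300 nM.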

Compound 4, inhibition constant: 143 nM
Estimate against measurement, compound 4: 1.2-fold (0.08 log units) below; the measured number falls inside the stated range.
By their numbers in this assay, from the lowest: compounds 2 and 1 (each within the scatter of the next); then compounds 3 and 4 (each within the scatter of the next).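

At this position, ortho to a hydroxy group and meta to a methoxy group, the two halogens cannot be told apart in this assay (a 1.2-fold higher number from compound 3 to compound 4 (0.07 log units; within the scatter)). The rise seen on adding chloro is therefore not peculiar to chloro, since bromo in place of hydrogen also gives a step beyond the scatter (a 3.9-fold higher number from compound 1 to compound 4 (0.59 log units; beyond the scatter)). In these compounds, what separates the values at this position is the presence of a halogen, not which of the two halogens it is.

From the compounds shown here alone, whether fluoro, a methyl or an amine at this position would behave like chloro and bromo remains open, as does whether the halogen step holds on the different chain of compound 2. Nothing in the data accounts for the halogen steps.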